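The source may report more compounds than this note shows. Statements on the series, on what has been measured and on what is new or still open speak of the compounds shown alone.

Working notes on the series, step from compound 2 to compound 3.

Among the compounds with values here, the two measured members are compound 1 `N#CC1=C(NCC(=O)N2CCOCC2)N(c2ccccc2)C(=O)N2CCCCC(N3CCCC3)C12` and compound 2 `N#CC1=C(/N=C/Nc2ccc([N+](=O)[O-])cc2)N(c2ccccc2)C(=O)N2CCCCC(N3CCCC3)C12`. In a functional assay on the whole organism (strain albino) for inhibition, with Rattus norvegicus as the target, read by paw edema, with stated times of 1 h and 3 h, at a dose of 20 mmol/kg by the intraperitoneal route (a lower number here means a weaker effect, a higher number a stronger effect of the compound at the dose given), compound 1 gives 73.5%, and compound 2 gives 85.6%. Within the data shown here, compound 2 thus stands highest of the two numbers, with compound 1 as its only neighbour, a step of a number 12.1 percentage points higher from compound 1 to compound 2 (beyond the scatter).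

The next member is compound 3 `N#CC1=C(NCC(=O)N2CCCC2)N(c2ccccc2)C(=O)N2CCCCC(N3CCCC3)C12`. It differs from compound 2 in one place: a group of 9 heavy atoms (6 carbon, 2 nitrogen, 1 oxygen; one five-membered non-aromatic ring with 1 hetero atom) in place of a group of 12 heavy atoms (7 carbon, 3 nitrogen, 2 oxygen; one six-membered aromatic ring of carbon only), on a double-bonded ring carbon. Among the measured compounds shown here, the entering group resembles the corresponding group of compound 1 more closely than the group it replaces, so the one measured step that bears on this change is the one from compound 1 to compound 2, which runs in the opposite direction to the present change. Reversing it suggests that the read-out in this assay for compound 3 is expected to fall back toward the value of compound 1, a step of a number 10.6 percentage points lower from compound 2 to compound 3 (beyond the scatter).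

Compound 3 is therefore estimated at 75% in this assay, with a range from 62% to 88%.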

Compound 3, a percentage reported as inhibition, in the whole organism at one dose (the size of the read-out at that dose, not a potency): 56%
Compound 3: the middle estimate sits 19 percentage points above what was measured; measured number below the stated range.
By their numbers in this assay, from the lowest: compound 3; then compound 1; then compound 2.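

In this assay, pyrrolidin-1-yl in place of morpholin-4-yl on a carbonyl carbon goes with a number 17.5 percentage points lower from compound 1 to compound 3 (beyond the scatter), so the two amide-bearing groups on the double-bonded ring carbon are not interchangeable. The step of a number 29.6 percentage points lower from compound 2 to compound 3 (beyond the scatter) therefore does not simply return the series to the level of compound 1, and compound 3 holds the lowest of the three numbers. No measurement accompanying these numbers accounts for the difference between the two amide rings.

Only morpholin-4-yl and pyrrolidin-1-yl are shown on the carbonyl carbon, leaving open how a piperidin-1-yl, a 4-methylpiperazin-1-yl or an open-chain dimethylamino group would read in this assay. The chain of compound 2 also stands alone, and the compounds shown do not separate the contribution of its nitro group from that of the rest of the chain, a question that the same chain with a plain phenyl ring or a chlorine in place of the nitro group would address.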